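Anilino to 3-hydroxyphenoxy on a phthalimide-linked chain

This account rests on a few compounds, and the source may have more. Where it says the series, first, only, none or still open, it means among the compounds named here.

Two measured compounds share a sulfonamide-bearing core. Compound 1 `Cc1ccc(S(=O)(=O)Nc2ccc3c(c2)C(=O)N(Cc2ccccc2F)C3=O)cc1` carries a 2-fluorophenyl group on the chain, and in an assay on isolated protein for inhibition of lactase/phlorizin hydrolase (Rattus norvegicus), read by colorimetric assay (a higher number here means a weaker inhibitor, a lower number a stronger inhibitor), compound 1 gives 180000 nM. Compound 2 `Cc1ccc(S(=O)(=O)Nc2ccc3c(c2)C(=O)N(CCNc2ccccc2)C3=O)cc1` carries an anilinomethyl group in its place, and in this assay compound 2 gives 177000 nM. The step of a 1.0-fold lower number from compound 1 to compound 2 (0.01 log units; within the scatter) shows that this exchange left the number essentially where it was. Compound 2 thus holds the lower of the two numbers, but its gap to compound 1 lies within the scatter, so no order between them can be read.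

Compound 3 `Cc1ccc(S(=O)(=O)Nc2ccc3c(c2)C(=O)N(CCOc2cccc(O)c2)C3=O)cc1` is the next structure: 3-hydroxyphenoxy in place of anilino on a saturated chain carbon, two bonds along the chain from an amide-type nitrogen in a ring, that is, on a saturated chain carbon, two bonds along the chain from an amide-type nitrogen in a ring. Among the compounds with values here, the only measured step, a 1.0-fold lower number from compound 1 to compound 2 (0.01 log units; within the scatter), changed the group at the end of this chain without moving the number beyond the scatter, and nothing measured speaks to a hydroxyphenoxy group. The reviewer therefore expects a step of about a 1.0-fold lower number from compound 2 to compound 3 (0.02 log units; within the scatter) in this assay, in no clear direction. For compound 3 the estimate in this assay is 170000 nM, with a range from 60000 nM to 500000 nM.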

Compound 3, half-maximal inhibitory concentration: 111000 nM
Beside the measured number, compound 3's estimate is 1.5-fold (0.19 log units) above it; measured number inside the range.
By their numbers in this assay, from the lowest: compounds 3, 2 and 1 (each within the scatter of the next).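

In this assay, putting 3-hydroxyphenoxy in place of anilino on a saturated chain carbon, two bonds along the chain from an amide-type nitrogen in a ring, gives a 1.6-fold lower number from compound 2 to compound 3 (0.20 log units; within the scatter) and so does not separate the two groups. The wider exchange, (3-hydroxyphenoxy)methyl in place of 2-fluorophenyl on a saturated chain carbon bound to an amide-type nitrogen in a ring, gives a 1.6-fold lower number from compound 1 to compound 3 (0.21 log units; within the scatter) and shows that even the two end groups furthest apart in this set, one carrying oxygen and the other fluorine, cannot be told apart here. With a third end group, and oxygen now in the place of the anilino nitrogen, this position has still produced no step beyond the scatter, and nothing available accounts for how close the numbers lie.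

The compounds shown leave open whether a plain phenoxy group, without the hydroxy, would read the same, so the ether oxygen and the hydroxy cannot be weighed separately. They also leave open whether an amine, a carboxylic acid or a longer chain at this position would move the number beyond the scatter.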